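A few compounds are considered here, and "the series" means these few. Any claim that something is new, unique, unknown or untested is made for them only; others in the source may bear on it.

Measured so far in a functional assay on KB cells (Homo sapiens) for cytotoxicity; on this read-out higher numbers stand for weaker inhibition and lower numbers for stronger inhibition:
- compound 1 `COc1ccc(S(=O)(=O)N2CCc3cccc(NC(=O)c4cccs4)c32)cc1`: 47 nM
- compound 2 `COc1ccc(S(=O)(=O)N2CCc3cccc(NC(=O)c4ccncc4)c32)cc1`: 9.6 nM
- compound 3 `COc1ccc(S(=O)(=O)N2CCc3cc(Br)cc(NC(=O)c4ccncc4)c32)cc1`: 91 nM

Of these three, compound 2 has the lowest number, 9.6 nM, which makes it the strongest inhibitor in this assay. Still unmeasured, compound 4 `COc1ccc(S(=O)(=O)N2CCc3cccc(NC(=O)c4ccco4)c32)cc1` differs from it in one place, with furan-2-yl in place of pyridin-4-yl on a carbonyl carbon.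

Two measured steps are available. The more relevant is a 4.9-fold lower number from compound 1 to compound 2 (0.69 log units; beyond the scatter), where pyridin-4-yl took the place of thiophen-2-yl on that same carbonyl carbon. Compound 4 goes the opposite way, from pyridin-4-yl back to a five-membered aromatic ring with 1 hetero atom, so a modest rise in the number is expected. The other step, a 9.5-fold higher number from compound 2 to compound 3 (0.98 log units; beyond the scatter), is a different change, bromo in place of hydrogen on an aromatic carbon, and offers little guidance here. For the measured compounds named here, no furan-2-yl compound has been measured yet, so the expectation remains loose.

The expected change is a 3.6-fold higher number from compound 2 to compound 4 (0.56 log units; beyond the scatter). For compound 4 the estimated value is 35 nM, with an expected range from 12 nM to 100 nM.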

Compound 4, half-maximal inhibitory concentration: 9.6 nM
Compound 4: the middle estimate sits 3.6-fold (0.56 log units) above what was measured; the measured number lies below the stated range.
By their numbers in this assay, from the lowest: compounds 2 and 4 (each within the scatter of the next); then compounds 1 and 3 (each within the scatter of the next).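

In this assay there is no change at the digits printed from compound 2 to compound 4 (within the scatter) when furan-2-yl takes the place of pyridin-4-yl on the carbonyl carbon, so a six-membered aromatic ring is not needed there for a low number. Ring size alone does not set the number either: there is a 4.9-fold lower number from compound 1 to compound 4 (0.69 log units; beyond the scatter) when furan-2-yl takes the place of thiophen-2-yl, a swap between two five-membered aromatic rings. Nothing at hand gives a reason for this difference between the two five-membered rings.

Still open, from the compounds shown here alone, is whether this carbonyl carbon needs an aromatic ring at all, or whether a non-aromatic group such as cyclohexyl or a short chain ending in an amine would also give a low number. Going by these compounds, it is also open whether adding bromo to compound 4 would raise the number as it did for compound 2.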